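Swapping the Oxadiazole of Compound 1 for a Carbamate

A few compounds are considered here, and "the series" means these few. Any claim that something is new, unique, unknown or untested is made for them only; others in the source may bear on it.

Measured compounds:
compound 1 `C[C@@H]1CN(c2nnc(C(F)(F)F)o2)CCN1c1ncc(OCc2ccc(OS(C)(=O)=O)cc2F)cn1`: 4 nM
compound 2 `C[C@@H]1CN(c2nnc(C(F)(F)F)o2)CCN1c1ncc(OCc2ccncc2C#N)cn1`: 28 nM
compound 3 `C[C@@H]1CN(c2nnc(C(F)(F)F)o2)CCN1c1ncc(OCc2ccc(CS(C)(=O)=O)cc2)cn1`: 150 nM

In a functional assay on HEK293S cells for agonist activity at Glucose-dependent insulinotropic receptor (Homo sapiens), read by HTRF and cAMP accumulation, with a stated time of 45 min (a higher number here means that more compound is needed for the effect, a lower number that less compound is needed), compound 1 gives the lowest number of the three, and both of its steps to the other compounds lie beyond the scatter: a 7.0-fold higher number from compound 1 to compound 2 (0.85 log units; beyond the scatter) and a 38-fold higher number from compound 1 to compound 3 (1.57 log units; beyond the scatter). The remaining step is a 5.4-fold higher number from compound 2 to compound 3 (0.73 log units; beyond the scatter). Every one of these steps alters the group on the saturated chain carbon bound to an oxygen on an aromatic ring; the group on the amine nitrogen in the ring is the same in all three.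

Compound 4 `C[C@@H]1CN(C(=O)OC2(C(F)(F)F)COC2)CCN1c1ncc(OCc2ccc(OS(C)(=O)=O)cc2F)cn1` keeps the benzyl portion of compound 1 and changes only that nitrogen: ((3-(trifluoromethyl)oxetan-3-yl)oxy)carbonyl in place of 5-(trifluoromethyl)-1,3,4-oxadiazol-2-yl on an amine nitrogen in a ring. Going by the values given here, no measured step bears on this position, so the three steps give no direct guide to its size or direction. With the rest of compound 1 retained, the number for compound 4 is expected to stay fairly close, with a modest rise as the more likely outcome, an expected step of a 3.8-fold higher number from compound 1 to compound 4 (0.57 log units; beyond the scatter). Compound 4 is therefore estimated at 15 nM, within a range of 3 nM to 80 nM.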

Compound 4, half-maximal effective concentration: 4 nM
Beside the measured number, compound 4's estimate is 3.8-fold (0.57 log units) above it; low and high end bracket the measured number.
By their numbers in this assay, from the lowest: compounds 1 and 4 (each within the scatter of the next); then compound 2; then compound 3.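

In this assay, the change on the amine nitrogen in the ring gives no change at the digits printed from compound 1 to compound 4 (within the scatter) and is the only reading shown at this position, as the earlier steps all altered the group on the saturated chain carbon. With the benzyl portion of compound 1 held fixed, this position accepts a ((3-(trifluoromethyl)oxetan-3-yl)oxy)carbonyl, with its four-membered non-aromatic ring, in place of the five-membered aromatic 5-(trifluoromethyl)-1,3,4-oxadiazol-2-yl without a change beyond the scatter. No available evidence accounts for this result.

As far as these compounds go, whether the same holds with the benzyl portions of compound 2 and compound 3 remains open, as the new group appears only with that of compound 1. Also open, from the compounds shown here alone, is how other groups on this nitrogen, such as a tert-butoxycarbonyl or an acetyl, would read.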